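Flipping One Ring Stereocentre in a Cytotoxicity Series

The source may report more compounds than this note shows. Statements on the series, on what has been measured and on what is new or still open speak of the compounds shown alone.

Compound 1 `CC(=O)NC[C@H]1CN(c2ccc(OC[C@@H]3CN(c4ccccc4)C(=O)O3)c(F)c2)C(=O)O1` gives > 5000 ug/mL in an ADME assay on Vero cells (Chlorocebus sabaeus) for cytotoxicity, read by MTT assay, with a stated time of 48 h (a higher number here means a weaker inhibitor, a lower number a stronger inhibitor), which is a limit of the assay rather than a number.
Compound 2 `CC(=O)NC[C@H]1CN(c2ccc(OC[C@H]3CN(c4ccccc4)C(=O)O3)c(F)c2)C(=O)O1` gives 63.6 ug/mL in this assay.
Compound 3 `COc1ccc(N2C[C@@H](COc3ccc(N4C[C@H](CNC(C)=O)OC4=O)cc3F)OC2=O)cc1` gives 19.1 ug/mL in this assay.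

Compound 3 has the lowest of the two real numbers; the nearest is compound 2, which sits beyond the scatter above it. Compound 4 `COc1ccc(N2C[C@H](COc3ccc(N4C[C@H](CNC(C)=O)OC4=O)cc3F)OC2=O)cc1` differs from compound 3 in that (the two compounds have the same atoms and bonds and differ only in configuration as drawn: 1 of 2 stereo elements differ; a stereocentre at a saturated ring carbon is drawn S in compound 3 and R in compound 4). The same flip at the same ring carbon was measured before: an at least 78-fold lower number from compound 1 to compound 2 (1.89 log units; beyond the scatter), and that step is only a lower bound since it starts from the limit of > 5000 ug/mL in this assay, at which 1 of the 3 values shown sits. The other measured step, an at least 260-fold lower number from compound 1 to compound 3 (2.41 log units; beyond the scatter), is not the change made here. A step of similar direction is therefore expected: for compound 4 the estimate is 10 ug/mL, between 3 ug/mL and 40 ug/mL, a step of a 1.9-fold lower number from compound 3 to compound 4 (0.28 log units; within the scatter).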

Compound 4, half-maximal inhibitory concentration: 107 ug/mL
For compound 4 the middle estimate is 11-fold (1.03 log units) below the measured one; the whole stated range lies below it.
By their numbers in this assay, from the lowest: compound 3; then compounds 2 and 4 (each within the scatter of the next). At a limit, above all of these: compound 1.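

The flip at this ring carbon does not act the same way on both cores in this assay: with methoxy it gives a 5.6-fold higher number from compound 3 to compound 4 (0.75 log units; beyond the scatter), against an at least 78-fold lower number from compound 1 to compound 2 (1.89 log units; beyond the scatter) without it. Compound 1 gives > 5000 ug/mL, a limit of the assay and not a number. With this carbon drawn R, methoxy in place of hydrogen gives a 1.7-fold higher number from compound 2 to compound 4 (0.23 log units; within the scatter), so the effect of that swap depends on the configuration drawn: the same change on two cores in this assay, an at least 260-fold lower number (2.41 log units; beyond the scatter) from compound 1 to compound 3 and a 1.7-fold higher number (0.23 log units; within the scatter) from compound 2 to compound 4, at least 440-fold (2.64 log units) apart, beyond the scatter of two such steps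

From the compounds shown here alone, whether an amine or a carboxylic acid in place of the methoxy would also turn the flip around remains open.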